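The source may hold more compounds than are shown below. What is called first, only, known or untested is meant among the compounds shown, and "the series" means these compounds.

In an ADME assay on cells (Astrocyte, Homo sapiens) for cytotoxicity, read by WST assay, with a stated time of 72 h (on this read-out higher numbers stand for weaker inhibition and lower numbers for stronger inhibition), compound 1 `O=C(Nc1cccc(Cl)c1)Nc1cc2ncncc2cc1OCc1cccc(Cl)c1` gives > 10000 nM, which is a limit of the assay and not a number. Within the data shown here, compound 2 `O=C(Nc1ccc(C(F)(F)F)cc1)Nc1cc2ncncc2cc1OCc1cccc(Cl)c1` gives 8800 nM, the only exact number so far. Its standing can be judged only against the limit of compound 1. Compound 3 `O=C(Nc1cccc(F)c1)Nc1cc2ncncc2cc1OCc1cccc(Cl)c1` has not yet been measured. It carries 3-fluorophenyl in place of 4-(trifluoromethyl)phenyl on an amide-type nitrogen, and the change counts as follows: 3-fluorophenyl in place of 4-(trifluoromethyl)phenyl on an amide-type nitrogen. Among the measured compounds shown here, only one measured step bears on this change, and it falls at the same place on an amide-type nitrogen. That step is an at least 1.1-fold lower number from compound 1 to compound 2 (0.05 log units; that floor lies within the scatter), and it came with 4-(trifluoromethyl)phenyl in place of 3-chlorophenyl. For the measured compounds named here, with only this small step as a guide, no shift beyond the scatter is expected in this assay, in either direction, and a reading reported only as a limit would be no surprise. The expected step is a 1.1-fold higher number from compound 2 to compound 3 (0.06 log units; within the scatter), which amounts to none beyond the scatter. For compound 3 the estimated value is 10000 nM, with an expected range of 5500 nM to 18000 nM.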

Compound 3, half-maximal inhibitory concentration: > 10000 nM
Compound 3: no number, only a limit; the forecaster's own chance of this, stated with the estimate: 55%; the middle value lies on the limit itself.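

In this assay, replacing 4-(trifluoromethyl)phenyl with 3-fluorophenyl on the amide-type nitrogen gives an at least 1.1-fold higher number from compound 2 to compound 3 (0.05 log units; that floor lies within the scatter), so this second change at the position also shows no shift that can be read as real. Across the three substituted phenyl groups now seen at this place, compound 2 remains the only one with an exact number, so the series offers no ordering of these groups. The step from compound 1 to compound 3, fluoro in place of chloro on an aromatic carbon, cannot be read, because both readings are limits of the assay and not numbers: the limit of > 10000 nM in this assay, at which 2 of the 3 values shown sit.

The compounds shown leave open whether any group at this place can move the reading beyond the scatter, and whether the phenyl ring itself matters to the result. An amine or a carboxylic acid on the phenyl ring, or a longer chain in its place, would add to the picture only if it gave an exact number rather than another limit.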